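Replacing 4-nitrophenyl with 2-fluorophenyl on the shared core

The compounds below may be only part of what the source reports. "The series", "measured", "known", "first", "only" and "open" are said of these compounds alone.

Compound 1 `C=C1C(=O)[C@@]23C(=O)OC[C@]4(C(=O)CCC(C)(C)[C@H]4C=O)[C@@H]2CC[C@@H]1[C@H]3OC(=O)c1ccc(C(F)(F)F)cc1`: 4930 nM
Compound 2 `C=C1C(=O)[C@@]23C(=O)OC[C@]4(C(=O)CCC(C)(C)[C@H]4C=O)[C@@H]2CC[C@@H]1[C@H]3OC(=O)c1ccc([N+](=O)[O-])cc1`: 3330 nM

In a functional assay on MGC-803 cells (Homo sapiens) for cytotoxicity, read by MTT assay, with a stated time of 72 h (a higher number here means a weaker inhibitor, a lower number a stronger inhibitor), compound 2 gives 3330 nM and stands level with compound 1, which gives 4930 nM. The gap between them stays within the usual scatter. Compound 3 `C=C1C(=O)[C@@]23C(=O)OC[C@]4(C(=O)CCC(C)(C)[C@H]4C=O)[C@@H]2CC[C@@H]1[C@H]3OC(=O)c1ccccc1F` keeps the shared core and differs from compound 2 in one place: 2-fluorophenyl in place of 4-nitrophenyl on a carbonyl carbon. Here 2-fluorophenyl stands in place of 4-nitrophenyl on a carbonyl carbon. Within the data shown here, only one measured step bears on this change, a 1.5-fold lower number from compound 1 to compound 2 (0.17 log units; within the scatter), which exchanged trifluoromethyl for nitro on an aromatic carbon. Among the measured compounds shown here, no measured compound carries 2-fluorophenyl, so that small step is only indirect guidance. The estimated step is a 1.2-fold higher number from compound 2 to compound 3 (0.08 log units; within the scatter), and no change beyond the scatter is expected. For compound 3 the estimated value in this assay is 4000 nM, with an expected range of 1800 nM to 9000 nM.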

Compound 3, half-maximal inhibitory concentration: 3940 nM
Beside the measured number, compound 3's estimate is 1.0-fold (0.01 log units) above it; low and high end bracket the measured number.
By their numbers in this assay, from the lowest: compounds 2, 3 and 1 (each within the scatter of the next).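

In this assay, putting 2-fluorophenyl in place of 4-nitrophenyl on the carbonyl carbon gives a 1.2-fold higher number from compound 2 to compound 3 (0.07 log units; within the scatter), and putting it in place of 4-(trifluoromethyl)phenyl gives a 1.3-fold lower number from compound 1 to compound 3 (0.10 log units; within the scatter). The earlier step exchanged only trifluoromethyl for nitro on an aromatic carbon, whereas these two steps exchange the whole aryl group, and the three compounds still stand level, so this position tolerates all three aryl groups without a change beyond the scatter. Nothing available here explains why these three groups read alike.

The compounds shown leave open whether an amine or a carboxylic acid on the phenyl ring would move the number beyond the scatter. Going by these compounds, it also remains open whether a longer alkyl chain in place of the ring would do so.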